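This account rests on a few compounds, and the source may have more. Where it says the series, first, only, none or still open, it means among the compounds named here.

Measured compounds:
Compound 1, `O=C(Nc1cccc(-n2cc(-c3ccncc3)c(-c3ccc(Cl)c(O)c3)n2)c1)Nc1cccc(C(F)(F)F)c1`: 2010 nM
Compound 2, `COc1cc(-c2nn(-c3cccc(NC(=O)Nc4cc(C(F)(F)F)cc(C(F)(F)F)c4)c3)cc2-c2ccncc2)ccc1Cl`: 932 nM
Compound 3, `COc1cc(-c2nn(-c3cccc(NC(=O)Nc4cccc(C(F)(F)F)c4)c3)cc2-c2ccncc2)ccc1Cl`: 1400 nM

In a functional assay on SN12C cells (Homo sapiens) for inhibition, read by sulforhodamine B assay, with a stated time of 48 h (a lower number here means a stronger inhibitor of growth, a higher number a weaker inhibitor of growth), compound 2 gives the lowest of the three numbers; the gap to compound 3, a 1.5-fold higher number from compound 2 to compound 3 (0.18 log units; within the scatter), lies within the scatter, while compound 1 stands beyond it. The unmeasured compound 4, `O=C(Nc1cccc(-n2cc(-c3ccncc3)c(-c3ccc(Cl)c(O)c3)n2)c1)Nc1cc(C(F)(F)F)cc(C(F)(F)F)c1`, differs from compound 2 by hydrogen in place of methyl on an oxygen on an aromatic ring, the methoxy becoming a hydroxy on the 4-chloro-3-methoxyphenyl, which thus becomes a 4-chloro-3-hydroxyphenyl. Within the data shown here, one measured step bears directly on this change, read in the opposite direction: a 1.4-fold lower number from compound 1 to compound 3 (0.16 log units; within the scatter), a shift within the scatter. Nothing in the three measured compounds suggests that this same exchange should behave differently on the bis(trifluoromethyl) urea of compound 2. The step from compound 2 to compound 4 in this assay is therefore expected to be small, most likely a slightly higher number and in any case not clearly beyond the scatter, a 1.4-fold higher number from compound 2 to compound 4 (0.14 log units; within the scatter). Compound 4 is accordingly estimated at 1300 nM, with a range from 550 nM to 3200 nM.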

Compound 4, concentration for 50% growth inhibition: 1030 nM
For compound 4 the middle estimate is 1.3-fold (0.10 log units) above the measured one; the measured number falls inside the stated range.
By their numbers in this assay, from the lowest: compounds 2, 4, 3 and 1 (each within the scatter of the next, the first and the last beyond it).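

In this assay, the exchange of methoxy for hydroxy on the 4-chloro-3-methoxyphenyl now has a reading on a second core, a 1.1-fold higher number from compound 2 to compound 4 (0.04 log units; within the scatter), and on both cores the step stays within the scatter: the same change on two cores in this assay, a 1.4-fold lower number (0.16 log units; within the scatter) from compound 1 to compound 3 and a 1.1-fold lower number (0.04 log units; within the scatter) from compound 4 to compound 2, 1.3-fold (0.11 log units) apart, within the scatter of two such steps. The added trifluoromethyl can now also be read with the hydroxy in place, a 2.0-fold lower number from compound 1 to compound 4 (0.29 log units; within the scatter), and this step agrees with its counterpart in the methoxy pair: the same change on two cores in this assay, a 1.5-fold higher number (0.18 log units; within the scatter) from compound 2 to compound 3 and a 2.0-fold higher number (0.29 log units; within the scatter) from compound 4 to compound 1, 1.3-fold (0.11 log units) apart, within the scatter of two such steps. Across these four compounds, neither change shows any measurable dependence on the other.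

Going by these compounds, it remains open whether a longer chain on the oxygen, such as ethyl or propyl, or an amine in place of the hydroxy would move the number beyond the scatter. On these data alone, whether either change behaves the same way in other cell lines also remains open.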